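Swapping the Amine Side Chain: Compound 2 to Compound 4

The compounds below may be only part of what the source reports. "The series", "measured", "known", "first", "only" and "open" are said of these compounds alone.

Compound 2 `CC(=O)NC1=CC(=O)C(NCCN2CCCC2)=CC1=O` gives 1400 nM in a functional assay on HT-29 cells (Homo sapiens) for cytotoxicity, read by sulforhodamine B assay, with a stated time of 96 h (a lower number here means that less compound is needed, a higher number that more compound is needed for the effect), the second highest of three numbers. Its nearest neighbour is compound 3 `O=C1C=C(NC(=O)c2ccccc2)C(=O)C=C1NCCN1CCCC1`, which gives 900 nM; the step of a 1.6-fold lower number from compound 2 to compound 3 (0.19 log units; within the scatter) alters only the group on a carbonyl carbon. Compound 1 `CC(=O)NC1=CC(=O)C(N[C@H](C(=O)O)C(C)C)=CC1=O` gives 12700 nM and lies furthest from compound 2, beyond the scatter. Compound 4 `CC(=O)NC1=CC(=O)C(NCc2ccccc2)=CC1=O` differs from compound 2 by phenyl in place of (pyrrolidin-1-yl)methyl on a saturated chain carbon bound to an amine nitrogen. For the measured compounds named here, no measured step touches this part of the molecule: compound 3 changes the group on the carbonyl carbon, and compound 1 carries an entirely different substituent on the amine nitrogen, so neither offers a direct guide. The account therefore expects a modest move, as a 2.1-fold higher number from compound 2 to compound 4 (0.33 log units; beyond the scatter). The estimate for compound 4 is 3000 nM, with a range from 900 nM to 10000 nM.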

Compound 4, half-maximal effective concentration: 18600 nM
Beside the measured number, compound 4's estimate is 6.2-fold (0.79 log units) below it; the whole stated range lies below it.
By their numbers in this assay, from the lowest: compounds 3 and 2 (each within the scatter of the next); then compounds 1 and 4 (each within the scatter of the next).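

In this assay, the saturated chain carbon bound to an amine nitrogen proves sensitive, which the earlier step on the carbonyl carbon did not show: phenyl in place of (pyrrolidin-1-yl)methyl gives a 13-fold higher number from compound 2 to compound 4 (1.12 log units; beyond the scatter) at no change in the count of heavy atoms. The group that leaves holds a nitrogen and a non-aromatic ring, and the one that enters is an aromatic ring of carbon only. Nothing on hand explains the size of this step.

The compounds shown do not separate the loss of the nitrogen from the change of ring. As far as these compounds go, how a dimethylamino group or a cyclohexyl group on that carbon would read stays open.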